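The source may report more compounds than this note shows. Statements on the series, on what has been measured and on what is new or still open speak of the compounds shown alone.

Three compounds share one core and differ only in the group attached to an oxygen on the aromatic ring. Compound 1 `NCCOCCOc1ccc([C@H]2CC[C@]3(CC2)OOC2(O3)C3CC4CC(C3)CC2C4)cc1` and compound 2 `c1cc([C@H]2CC[C@]3(CC2)OOC2(O3)C3CC4CC(C3)CC2C4)ccc1OCCOC1CCNCC1` carry open chains that end in an amine. In an ADME assay on microsomes from liver (Homo sapiens) for metabolic stability, read by LC-MS, tested at 1 uM (a higher number here means faster removal of the compound, a lower number slower removal), compound 1 gives < 7 mL.min-1.g-1, which is a limit of the assay rather than a number. Compound 2 likewise gives < 7 mL.min-1.g-1, again a limit. Compound 3 `CC(C)(O)CN1CCC(Oc2ccc([C@H]3CC[C@]4(CC3)OOC3(O4)C4CC5CC(C4)CC3C5)cc2)CC1` is the only one of the three with a true number: in this assay compound 3 gives 18 mL.min-1.g-1. So compound 3 stands as the one measurable value, and two steps lead to it: an at least 2.5-fold higher number from compound 1 to compound 3 (0.41 log units; beyond the scatter) and an at least 2.5-fold higher number from compound 2 to compound 3 (0.41 log units; beyond the scatter). Both run the same way, toward faster removal, and both rest on (the limit of < 7 mL.min-1.g-1 in this assay, at which 2 of the 3 values shown sit).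

Compound 4 `CC(C)(CN)Oc1ccc([C@H]2CC[C@]3(CC2)OOC2(O3)C3CC4CC(C3)CC2C4)cc1` is not yet measured. It differs from compound 3 in one place: 1-(aminomethyl)-1-methylethyl in place of 1-(2-hydroxy-2-methylpropyl)piperidin-4-yl on an oxygen on an aromatic ring. The change removes the six-membered ring and brings in a shorter branched group with an amine, so that what hangs off the oxygen in compound 4 resembles compound 1 more than compound 3. Both measured steps toward compound 3 ran upward. The step from compound 3 to compound 4 is therefore expected to run the other way, a 2.6-fold lower number from compound 3 to compound 4 (0.41 log units; beyond the scatter). Compound 4 is estimated at 7 mL.min-1.g-1, within 3 mL.min-1.g-1 to 16 mL.min-1.g-1, with a real chance that only a limit is reported.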

Compound 4, intrinsic clearance in microsomes: < 7 mL.min-1.g-1
Compound 4 ended at the assay's limit; the forecaster's own chance of this, stated with the estimate: 50%; the middle value lies on the limit itself.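

In this assay, exchanging the 1-(2-hydroxy-2-methylpropyl)piperidin-4-yl group for the much smaller 1-(aminomethyl)-1-methylethyl group gives an at least 2.5-fold lower number from compound 3 to compound 4 (0.41 log units; beyond the scatter), a step whose size is only a minimum since compound 4 gives a limit and not a number. Among the compounds shown here, this is the first step that leads away from compound 3 to a group with no ring at all, and it shows that a short branched chain ending in an amine lands at the same limit as the two longer groups of compound 1 and compound 2, which leaves compound 3 as the only one of the four with a true number. The steps from compound 1 and from compound 2 to compound 4 join two limits and cannot be read, and any ranking among these three is out of reach, as all of this rests on one floor of the assay: the limit of < 7 mL.min-1.g-1 in this assay, at which 3 of the 4 values shown sit.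

The change takes away the ring, the hydroxy group and the carbons on the piperidine nitrogen all at once, so the compounds shown cannot tell which of these parts goes with the faster removal of compound 3. As far as these compounds go, a plain piperidin-4-yl on the same oxygen, or a 1-(hydroxymethyl)-1-methylethyl group in place of the aminomethyl version, would pull these parts apart, and how either behaves remains open.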